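Methoxy for Hydroxymethyl on a Pair Sitting at the Limit

A few compounds are considered here, and "the series" means these few. Any claim that something is new, unique, unknown or untested is made for them only; others in the source may bear on it.

Compound 1 `Nc1nc(-c2cccc(CO)c2)nc2sc(-c3ccccc3)nc12` gives > 30000 nM in a functional assay on CHO cells for antagonist activity at adenosine receptor A2b (Homo sapiens), read by cAMP accumulation, with a stated time of 10 min; on this read-out lower numbers stand for stronger inhibition and higher numbers for weaker inhibition.
Compound 2 `COc1ccc(-c2nc(N)c3nc(-c4ccccc4)sc3n2)cc1` gives > 30000 nM in this assay.

Compound 1 stands only at a limit of the assay, not at a number. For the measured compounds named here, the one further value shown, for compound 2, is a limit as well. Going by the values given here, the single measured step, a step that the two limits leave unreadable from compound 1 to compound 2, therefore cannot be read in size or direction, as the limit of > 30000 nM in this assay, at which 2 of the 2 values shown sit, shows: both values shown sit at the same limit.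

Compound 3 `COc1cccc(-c2nc(N)c3nc(-c4ccccc4)sc3n2)c1` differs from compound 1 by methoxy in place of hydroxymethyl on an aromatic carbon. Compound 2 carries the same methoxy, set at a different position on the same ring, and it sits at the limit like compound 1. No measured step speaks directly to the change from compound 1 to compound 3, and the one step shown, from compound 1 to compound 2, is unreadable; nothing in the data points to a step beyond the scatter in this assay in either direction.

Compound 3 is therefore expected to remain at the limit, with an estimate of 40000 nM and a range from 15000 nM to 100000 nM. The expected step that the limit leaves unreadable from compound 1 to compound 3 is none beyond the scatter.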

Compound 3, half-maximal inhibitory concentration: > 30000 nM
Compound 3: only a limit was reported; the forecaster's own chance of this, stated with the estimate: 85%; the middle value lies beyond the limit too.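

No step among compound 1, compound 2 and compound 3 can be read, since all three stand at one limit of the assay and not at a number: the limit of > 30000 nM in this assay, at which 3 of the 3 values shown sit.

The compounds shown leave open whether methoxy and hydroxymethyl, or 3-methoxyphenyl and 4-methoxyphenyl, differ at all on the shared core, and which change to it would give a readable value.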